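The source may report more compounds than this note shows. Statements on the series, on what has been measured and on what is new or still open speak of the compounds shown alone.

Measured in an ADME assay on HepG2 cells (Homo sapiens) for inhibition, read by fluorescence and resazurin assay, with a stated time of 72 h; a higher number here means a weaker inhibitor, a lower number a stronger inhibitor:
Compound 1 `CS(=O)(=O)Nc1cccc(Nc2nccc(Nc3ccc4nc[nH]c4c3)n2)c1`: > 25000 nM, a limit of the assay.
Compound 2 `NS(=O)(=O)c1ccc(Nc2nccc(Nc3ccc4nc[nH]c4c3)n2)cc1`: > 25000 nM, a limit of the assay.
Compound 3 `NS(=O)(=O)c1ccc(Nc2nccc(Nc3ccc4cn[nH]c4c3)n2)cc1`: 22000 nM.

Compound 3 is the only one of these with a true number. The other two results are the limit of > 25000 nM in this assay, at which 2 of the 3 values shown sit.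

Compound 4 `NC(=O)c1ccc(Nc2nccc(Nc3ccc4cn[nH]c4c3)n2)cc1` has carbamoyl in place of sulfamoyl on an aromatic carbon, para to a large group: carbamoyl in place of sulfamoyl on an aromatic carbon. For the measured compounds named here, the only measured step, an at least 1.1-fold lower number from compound 2 to compound 3 (0.05 log units; that floor lies within the scatter), lies within the scatter and concerns a different group. Going by the values given here, no measured step covers this exchange, so no change beyond the scatter is foreseen in this assay. The expected step is no change at the digits printed from compound 3 to compound 4 (within the scatter). For compound 4 the estimated value is 22000 nM, with an expected range from 10000 nM to 45000 nM.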

Compound 4, half-maximal inhibitory concentration: 16000 nM
Beside the measured number, compound 4's estimate is 1.4-fold (0.14 log units) above it; measured number inside the range.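

In this assay, carbamoyl in place of sulfamoyl on an aromatic carbon, para to a large group, gives a 1.4-fold lower number from compound 3 to compound 4 (0.14 log units; within the scatter). Unlike the earlier step, which rests on a limit, this one joins two true numbers, and it shows that this exchange at this position brings no change beyond the scatter. The part of the scale that can be read remains small: the limit of > 25000 nM in this assay, at which 2 of the 4 values shown sit.

The compounds shown leave open whether an amine, a carboxylic acid or a longer chain at this position would move the number beyond the scatter.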